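A few compounds are considered here, and "the series" means these few. Any claim that something is new, unique, unknown or untested is made for them only; others in the source may bear on it.

Compound 1: `COc1ccc(/C=N/Nc2nc(N)c3ncn([C@@H]4O[C@H](CO)[C@@H](O)[C@H]4O)c3n2)cn1` — 2.6 nM
Compound 2: `Nc1nc(N/N=C/c2ccc(C(F)(F)F)cc2C(F)(F)F)nc2c1ncn2[C@@H]1O[C@H](CO)[C@@H](O)[C@H]1O` — > 10000 nM

Among the compounds with values here, in an assay on CHO-K1 cells for displacement of a labelled ligand from adenosine receptor A1 (Homo sapiens), read by scintillation counting, with a stated time of 60 min (on this read-out lower numbers stand for stronger inhibition and higher numbers for weaker inhibition), compound 1 gives 2.6 nM, the only actual number among the values so far. Compound 2 returns only > 10000 nM, which is a limit of the assay rather than a measured number. In this assay compound 2 thus sits at the limit of > 10000 nM in this assay, at which 1 of the 2 values shown sits. Within the data shown here, no step between two measured compounds is given, so nothing yet says how a change of the group on the carbon with a double bond to nitrogen shifts the binding.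

Compound 3, `Nc1nc(N/N=C/c2ccc(-n3ccnc3)cc2)nc2c1ncn2[C@@H]1O[C@H](CO)[C@@H](O)[C@H]1O`, is the next compound to be measured. It differs from compound 1 in one place: 4-(1H-imidazol-1-yl)phenyl in place of 6-methoxypyridin-3-yl on a carbon with a double bond to nitrogen. The group that enters is larger and carries two rings in place of one. Without a measured step, the expectation rests on compound 1 alone, and a modest loss is expected, with a step from compound 1 to compound 3 of a 15-fold higher number from compound 1 to compound 3 (1.19 log units; beyond the scatter), somewhat beyond the usual scatter. Compound 3 is therefore estimated to give 40 nM in this assay, expected to fall between 5 nM and 800 nM.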

Compound 3, inhibition constant: > 10000 nM
Compound 3: a limit, no number (the forecaster's own chance of this, stated with the estimate: 15%); at least 250-fold (2.39 log units) between middle value and limit.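

In this assay, within the data shown here, the first step between two measured compounds that differ in one place is large: an at least 3800-fold higher number from compound 1 to compound 3 (3.58 log units; beyond the scatter). The value of compound 3, > 10000 nM, is a limit of the assay and not a number. So the group on the carbon with a double bond to nitrogen matters greatly for this read-out, since replacing 6-methoxypyridin-3-yl with 4-(1H-imidazol-1-yl)phenyl while the rest of the molecule stays the same is enough to reach that limit, and compound 3 now stands there with compound 2: the limit of > 10000 nM in this assay, at which 2 of the 3 values shown sit.

The compounds shown leave open which part of this change counts: the loss of the methoxy group, the loss of the pyridine ring nitrogen, or the arrival of the imidazole ring. Going by these compounds, a plain phenyl group on the same carbon, or a pyridine ring carrying an amine in place of the methoxy group, would help to separate these possibilities, and how far the binding of compound 3 lies past the limit also remains unknown.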